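Methoxy count on the aryl ring: from compound 2 to compound 4

The source may report more compounds than this note shows. Statements on the series, on what has been measured and on what is new or still open speak of the compounds shown alone.

Measured so far in a functional assay on RPMI-8226 cells (Homo sapiens) for inhibition, read by sulforhodamine B assay, with a stated time of 48 h; a lower number here means a stronger inhibitor of growth, a higher number a weaker inhibitor of growth:
compound 1 `COc1ccc(-c2cc(/C=C/C(=O)c3ccc(N)cc3)[nH]n2)cc1` — 3220 nM
compound 2 `COc1cc(-c2cc(/C=C/C(=O)c3ccc(N)cc3)[nH]n2)cc(OC)c1OC` — 2770 nM
compound 3 `COc1cc(-c2cc(/C=C/C(=O)c3ccc(F)c(F)c3)[nH]n2)cc(OC)c1OC` — 6010 nM

Compound 2 gives the lowest number of the three in this assay, but compound 1 sits within the scatter of it, so the two cannot be told apart. For the measured compounds named here, the one step beyond the scatter is a 2.2-fold higher number from compound 2 to compound 3 (0.34 log units; beyond the scatter), and it changes the aminophenyl ring on the carbonyl side, not the methoxy pattern.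

Compound 4 `COc1ccc(-c2cc(/C=C/C(=O)c3ccc(N)cc3)[nH]n2)cc1OC` differs from compound 2 by hydrogen in place of methoxy on an aromatic carbon. Going by the values given here, no measured step removes a single methoxy; compound 1 and compound 2, which differ by two methoxy groups, give numbers within the scatter of each other, and the step of a 2.2-fold higher number from compound 2 to compound 3 (0.34 log units; beyond the scatter) does not touch this ring. On these grounds the step of a 1.1-fold higher number from compound 2 to compound 4 (0.03 log units; within the scatter) is expected to stay within the scatter. Compound 4 is therefore estimated at 3000 nM in this assay, with a range of 1500 nM to 6000 nM.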

Compound 4, concentration for total growth inhibition: 5520 nM
Compound 4: the middle estimate sits 1.8-fold (0.26 log units) below what was measured; the measured number falls inside the stated range.
By their numbers in this assay, from the lowest: compounds 2, 1, 4 and 3 (each within the scatter of the next, the first and the last beyond it).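

In this assay, a single methoxy change on this ring can now be read directly: hydrogen in place of methoxy gives a 2.0-fold higher number from compound 2 to compound 4 (0.30 log units; within the scatter), and methoxy in place of hydrogen gives a 1.7-fold higher number from compound 1 to compound 4 (0.23 log units; within the scatter). Both steps lie within the scatter, so neither taking one methoxy from the trimethoxy pattern nor adding one to the single-methoxy pattern separates the compounds, and compounds 1, 2 and 4 cannot be told apart by methoxy count while the 4-aminophenyl group is kept. Nothing available here accounts for these numbers.

From the compounds shown here alone, whether a hydroxy or an ethoxy group on this aromatic carbon would give a step beyond the scatter remains open. Also open, going by these compounds, is whether the same methoxy change stays within the scatter with 3,4-difluorophenyl on the carbonyl carbon.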